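Swapping a chlorine for a methoxy on a melanocortin-4 ligand

The compounds below may be only part of what the source reports. "The series", "measured", "known", "first", "only" and "open" are said of these compounds alone.

Of the compounds shown here, two have been measured in an assay on HEK293 cells for displacement of a labelled ligand from Melanocortin receptor 4 (Homo sapiens); a higher number here means a weaker inhibitor, a lower number a stronger inhibitor. Compound 1, `CC(C)C[C@H](N)c1ccccc1N1CCN(C(=O)[C@H](C)Cc2ccc(Cl)cc2F)CC1`, gives 67 nM in this assay. Compound 2, `CC(C)C[C@H](N)c1cc(C(F)(F)F)ccc1N1CCN(C(=O)[C@H](C)Cc2ccc(Cl)cc2)CC1`, gives 31 nM in this assay, the lower of the two numbers and therefore the stronger inhibitor, since the gap to compound 1 lies beyond the usual scatter of repeated measurements. The two compounds differ in more than one place, so no single change can be read from that gap.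

Compound 3, `COc1ccc(CC(C)C(=O)N2CCN(c3ccc(C(F)(F)F)cc3[C@@H](N)CC(C)C)CC2)cc1`, has not yet been measured in this assay. It differs from compound 2 in one place: 1-(4-methoxybenzyl)ethyl in place of 1-(4-chlorobenzyl)ethyl on a carbonyl carbon. Nothing in the measured pair shows how this particular exchange affects binding, so the expectation rests on the general picture that such replacements usually move the number by a small to moderate amount rather than a large one. A mild weakening is expected, so that the step from compound 2 to compound 3 in this assay comes out as a 2.3-fold higher number from compound 2 to compound 3 (0.35 log units; beyond the scatter). Compound 3 is accordingly estimated at 70 nM in this assay, within a range from 25 nM to 200 nM.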

Compound 3, inhibition constant: 120 nM
Compound 3: the middle estimate sits 1.7-fold (0.23 log units) below what was measured, and the stated range covers the measured number.
By their numbers in this assay, from the lowest: compound 2; then compounds 1 and 3 (each within the scatter of the next).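

Going by these compounds alone, this is the first change that can be read on its own: in this assay, putting 1-(4-methoxybenzyl)ethyl in place of 1-(4-chlorobenzyl)ethyl on the carbonyl carbon gives a 3.9-fold higher number from compound 2 to compound 3 (0.59 log units; beyond the scatter), so binding responds to what is exchanged at this position. The step covers more than the swap of chlorine for a methoxy group, since the entering group carries a hydrogen-bond acceptor that the leaving group lacks, and the leaving group has a defined stereocentre while none is recorded for the entering group. Within the data shown here, no measurement available here explains why the number rises, and the single step cannot separate these differences.

On these data alone, it remains open whether the same group with a defined stereocentre would give a similar number, which would show how much of the step belongs to the methoxy group itself. Also unsettled is how a bromine, a methyl or a hydroxyl in place of the chlorine would compare, so one exchange cannot yet show what this position tolerates.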